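A few compounds are considered here, and "the series" means these few. Any claim that something is new, unique, unknown or untested is made for them only; others in the source may bear on it.

Working notes on the series.

Compound 1 `Cc1cc(C)c(S(=O)(=O)N2CCC(N3CN4CCC3CC4)CC2)c(C)c1` gives 2040 nM in an assay on isolated protein for inhibition of 7-dehydrocholesterol reductase (Homo sapiens); on this read-out higher numbers stand for weaker inhibition and lower numbers for stronger inhibition. Among the compounds with values here, compound 2 `Cc1cc(C)c(S(=O)(=O)N2CCC([N+]3(C)CCCC3)CC2)c(C)c1` gives 50000 nM in this assay, the highest of the two numbers so far; its nearest neighbour is compound 1, and a 25-fold higher number from compound 1 to compound 2 (1.39 log units; beyond the scatter).

Compound 3 `Cc1cc(C)c(S(=O)(=O)N2CCC(N3CCCCCC3)CC2)c(C)c1` has not been measured in this assay. Compared with compound 2, (a group of 7 heavy atoms (6 carbon, 1 nitrogen; one seven-membered non-aromatic ring with 1 hetero atom) in place of a group of 6 heavy atoms (5 carbon, 1 nitrogen; one five-membered non-aromatic ring with 1 hetero atom), on a saturated ring carbon). The group that leaves carries net charge +1; the azepan-1-yl that enters has no net charge and one hydrogen-bond acceptor.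

Within the data shown here, only one measured step bears on this change: the large one, a 25-fold higher number from compound 1 to compound 2 (1.39 log units; beyond the scatter), in which the group with net charge +1 came in on the same saturated ring carbon and the number rose far beyond the scatter. Removing that group again is expected to reverse much of that, so a large step downward in this assay is expected, a 33-fold lower number from compound 2 to compound 3 (1.52 log units; beyond the scatter).

For compound 3 the estimate in this assay is 1500 nM, within 300 nM to 8000 nM.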

Compound 3, half-maximal inhibitory concentration: 1390 nM
Estimate against measurement, compound 3: 1.1-fold (0.03 log units) above, within the range that was stated.
By their numbers in this assay, from the lowest: compounds 3 and 1 (each within the scatter of the next); then compound 2.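

In this assay, azepan-1-yl on this saturated ring carbon, in place of the group with net charge +1, gives a 36-fold lower number from compound 2 to compound 3 (1.56 log units; beyond the scatter). The comparison with the larger two-ring group of compound 1 reads a 1.5-fold lower number from compound 1 to compound 3 (0.17 log units; within the scatter), so among these three compounds only compound 2 stands apart at this position, while compound 1 and compound 3 cannot be told apart despite their different groups. No measurement at hand accounts for the separate standing of compound 2.

As far as these compounds go, both steps from compound 2 change ring size and net charge together, so the contribution of each remains open. The uncharged pyrrolidin-1-yl would keep the five-membered ring without the charge, and piperidin-1-yl would show how the six-membered ring fits among these groups.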